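Core series: replacing benzylamino with 4-methylpiperidin-1-yl

This account rests on a few compounds, and the source may have more. Where it says the series, first, only, none or still open, it means among the compounds named here.

Measured in a functional assay on NCI-H460 cells (Homo sapiens) for antiproliferative activity, read by CCK-8 assay, with a stated time of 72 h, tested at 2 uM; a higher number here means a stronger effect of the compound at the concentration tested, a lower number a weaker effect:
compound 1 `Cc1ccc(Nc2nc(Cl)nc3c2ncn3Cc2ccc(C(=O)Nc3ccccc3N)cc2)cc1` gives 67.3%
compound 2 `Nc1ccccc1NC(=O)c1ccc(Cn2cnc3c(NCc4ccccc4)nc(Cl)nc32)cc1` gives 44.7%
compound 3 `Nc1ccccc1NC(=O)c1ccc(Cn2cnc3c(Nc4ccc(-c5ccccn5)cc4)nc(Cl)nc32)cc1` gives 18.1%

Compound 2 stands second of the three numbers in this assay: compound 1 lies above it, compound 3 below it, each beyond the scatter. The measured steps change only the group carried on the nitrogen of the shared core: a number 22.6 percentage points lower from compound 1 to compound 2 (beyond the scatter), a number 26.6 percentage points lower from compound 2 to compound 3 (beyond the scatter) and a number 49.2 percentage points lower from compound 1 to compound 3 (beyond the scatter). Each keeps that nitrogen bearing a hydrogen.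

Compound 4 `CC1CCN(c2nc(Cl)nc3c2ncn3Cc2ccc(C(=O)Nc3ccccc3N)cc2)CC1` differs from compound 2 as follows: 4-methylpiperidin-1-yl in place of benzylamino on an aromatic carbon. Among the measured compounds shown here, no measured step exchanges the nitrogen-bound group for a ring attached through its own ring nitrogen, so none bears directly on this change. What the series shows is that variation at this position moves this assay by modest to large amounts in either direction. With no guide to the direction, compound 4 is expected near compound 2, with a wide range: the estimated step is a number 4.7 percentage points lower from compound 2 to compound 4 (within the scatter). Compound 4 is therefore estimated at 40%, between 15% and 65%.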

Compound 4, a percentage reported as inhibition, at one concentration (the size of the read-out at that concentration, not a potency): 11.8%
Compound 4: the middle estimate sits 28.2 percentage points above what was measured; the measured number lies below the stated range.
By their numbers in this assay, from the lowest: compounds 4 and 3 (each within the scatter of the next); then compound 2; then compound 1.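

In this assay, among the compounds shown here, 4-methylpiperidin-1-yl is the first group at this position that is attached through a ring nitrogen and carries no hydrogen on that nitrogen, and it gives large drops: a number 32.9 percentage points lower from compound 2 to compound 4 (beyond the scatter) and a number 55.5 percentage points lower from compound 1 to compound 4 (beyond the scatter). A hydrogen on the attached nitrogen does not by itself hold the number up, as compound 3 keeps it and still gives 18.1%, within the scatter of compound 4 at 11.8%. Nothing available explains the drop.

The change removes the amino hydrogen and also swaps the aromatic ring for a non-aromatic one, so the compounds shown do not separate these two differences. Cyclohexylamino and benzyl(methyl)amino groups at this position would each alter only one of them.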